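A few compounds are considered here, and "the series" means these few. Any claim that something is new, unique, unknown or untested is made for them only; others in the source may bear on it.

Compound 1 `CSc1cc(C(=O)N2CCc3ccccc32)cc(C#N)c1O`: in an assay on tissue (RPTEC cells) for inhibition of solute carrier family 22 member 12 (Homo sapiens), read by scintillation counting, with stated times of 15 min and 2 h (on this read-out lower numbers stand for stronger inhibition and higher numbers for weaker inhibition), compound 1 reaches only the limit of the assay, > 100000 nM.
Compound 2 `CC(C)(C)c1cc(C(=O)N2CCc3ccccc32)cc(C#N)c1O`: compound 2 gives 31600 nM.
Compound 3 `N#Cc1cc(C(=O)N2CCc3ccccc32)cc(Cl)c1O`: compound 3 gives 14700 nM.

Of the two numbers shown, compound 3 has the lower one; the nearest is compound 2, with a 2.1-fold lower number from compound 2 to compound 3 (0.33 log units; beyond the scatter). Compound 4 `N#Cc1cc(C(=O)N2CCc3ccccc32)cc(C(F)(F)F)c1O` differs from compound 3 by trifluoromethyl in place of chloro on an aromatic carbon. All three measured steps alter this same aromatic carbon: an at least 3.1-fold lower number from compound 1 to compound 2 (0.50 log units; beyond the scatter), an at least 6.8-fold lower number from compound 1 to compound 3 (0.83 log units; beyond the scatter) and a 2.1-fold lower number from compound 2 to compound 3 (0.33 log units; beyond the scatter). Every swap here shifted the number, yet between the two numbered compounds the shift was modest. For the swap to trifluoromethyl, a step of about a 1.4-fold higher number from compound 3 to compound 4 (0.13 log units; within the scatter) is expected, which would stay within the scatter. Compound 4 is therefore expected to give roughly 20000 nM, between 7000 nM and 60000 nM.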

Compound 4, half-maximal inhibitory concentration: > 100000 nM
Compound 4 was reported as a limit (the forecaster's own chance of this, stated with the estimate: 10%); middle value at least 5.0-fold (0.69 log units) away from the limit.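

Among the groups shown, this aromatic carbon tolerates change less than the earlier modest step suggested: trifluoromethyl in place of chloro gives an at least 6.8-fold higher number from compound 3 to compound 4 (0.83 log units; beyond the scatter), and trifluoromethyl in place of tert-butyl gives an at least 3.1-fold higher number from compound 2 to compound 4 (0.50 log units; beyond the scatter). Compound 4 joins compound 1 at the assay limit, leaving only chloro and tert-butyl with readable numbers here: the limit of > 100000 nM in this assay, at which 2 of the 4 values shown sit. The step between compound 1 and compound 4 cannot be read.

Going by these compounds, whether methyl, fluoro, an amine or a carboxylic acid at this carbon would give a lower number than chloro stays open. On these data alone, how far compound 1 and compound 4 lie past the limit also stays unknown.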